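This account rests on a few compounds, and the source may have more. Where it says the series, first, only, none or still open, it means among the compounds named here.

Measured compounds:
- compound 1, `CC(C)c1ccc(Nc2ccc3c(OCCCN4CCN(C)CC4)cccc3n2)cc1`, 16400 nM in a functional assay on A498 cells (Homo sapiens) for inhibition, read by sulforhodamine B assay, with a stated time of 48 h; a lower number here means a stronger inhibitor of growth, a higher number a weaker inhibitor of growth
- compound 2, `CN1CCN(CCCOc2cccc3nc(Nc4ccc(F)c(F)c4)ccc23)CC1`, 5660 nM in this assay

Within the data shown here, compound 2 stands at the lowest of the two numbers in this assay; its only neighbour is compound 1, which gives 16400 nM. Among the measured compounds shown here, the single measured step, a 2.9-fold lower number from compound 1 to compound 2 (0.46 log units; beyond the scatter), came with a change of the aryl group on the nitrogen on the aromatic ring and was modest, though beyond the scatter.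

Compound 3, `CN1CCN(CCCOc2cccc3nc(Nc4cccc(Cl)c4)ccc23)CC1`, keeps the shared core of compound 2 and differs only in that aryl group: 3-chlorophenyl in place of 3,4-difluorophenyl on a nitrogen on an aromatic ring. The step from compound 1 to compound 2 is the only one that bears on this change, and it shows that swapping one halogenated or alkylated phenyl for another moves this assay by a modest amount at most. Nothing else constrains the direction, so the expectation for compound 3 is a step no larger than the scatter, a 1.1-fold higher number from compound 2 to compound 3 (0.03 log units; within the scatter). The estimate for compound 3 in this assay is 6000 nM, with a range from 2500 nM to 14000 nM.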

Compound 3, concentration for 50% growth inhibition: 1880 nM
Compound 3: the middle estimate sits 3.2-fold (0.50 log units) above what was measured; the measured number lies below the stated range.
By their numbers in this assay, from the lowest: compound 3; then compound 2; then compound 1.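

Notes on the aryl group on a nitrogen on an aromatic ring: this place is more responsive in this assay than the single earlier step could show, since 3-chlorophenyl in place of 3,4-difluorophenyl gives a 3.0-fold lower number from compound 2 to compound 3 (0.48 log units; beyond the scatter), a step beyond the scatter between two halogenated phenyl groups. Set against the 4-isopropylphenyl group, the same aryl group gives an 8.7-fold lower number from compound 1 to compound 3 (0.94 log units; beyond the scatter), which widens the span seen at this place, and compound 3 is now the strongest inhibitor of growth of the three, its steps to both others being beyond the scatter. No measurement at hand accounts for the difference between these aryl groups.

The change from 3,4-difluorophenyl to 3-chlorophenyl alters the kind of halogen and the number of halogens together, so the compounds shown do not separate these two contributions; 3-fluorophenyl, 4-chlorophenyl and 3,4-dichlorophenyl on the same nitrogen would pull them apart. Also open, on these data alone, is whether the trend continues with 3-bromophenyl or 3-methoxyphenyl, or with an unsubstituted phenyl as the plain reference for all three groups.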